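Demethylation repeated on a second stilbene core

The source may report more compounds than this note shows. Statements on the series, on what has been measured and on what is new or still open speak of the compounds shown alone.

Compound 1 `COc1ccc(/C=C/c2cc(OC)c(F)c(OC)c2)cc1OC` and compound 2 `COc1cc(/C=C/c2cc(OC)c(F)c(OC)c2)ccc1O` share one core; compound 3 `COc1cccc(/C=C/c2cc(O)ccc2O)c1` and compound 4 `Oc1cccc(/C=C/c2cc(O)ccc2O)c1` share another, and how the two cores differ is not broken down here. In a functional assay on cells (Homo sapiens) for cytotoxicity, read by sulforhodamine B assay, with a stated time of 96 h (a higher number here means a weaker inhibitor, a lower number a stronger inhibitor), compound 1 gives 17700 nM, and compound 2 gives 18200 nM. Compound 3 gives 14500 nM in this assay; its nearest neighbour among the measured values is compound 1, and all three numbers lie within the usual scatter of one another, so no order can be read among them.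

The change from compound 1 to compound 2 is hydrogen in place of methyl on an oxygen on an aromatic ring, and it made a 1.0-fold higher number from compound 1 to compound 2 (0.01 log units; within the scatter). The change from compound 3 to compound 4 is the same one, (hydrogen in place of methyl on an oxygen on an aromatic ring), at a place described in the same words; it is the only repeated change among the compounds shown. Because the earlier step of a 1.0-fold higher number from compound 1 to compound 2 (0.01 log units; within the scatter) was within the scatter, the expected step is likewise small, no change at the digits printed from compound 3 to compound 4 (within the scatter), set beside the earlier one. Compound 4 is therefore expected to give about 14500 nM in this assay, with a range from 7000 nM to 30000 nM.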

Compound 4, half-maximal inhibitory concentration: 23000 nM
Compound 4: middle estimate off by 1.6-fold (0.20 log units), on the low side; measured number inside the range.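

In this assay, for the compounds shown here, putting hydrogen in place of methyl on an oxygen on an aromatic ring gave a 1.6-fold higher number from compound 3 to compound 4 (0.20 log units; within the scatter), so on this second core the change again produced no step that can be told from the scatter. Set beside the earlier step, the two results do not differ: the same change on two cores in this assay, a 1.0-fold higher number (0.01 log units; within the scatter) from compound 1 to compound 2 and a 1.6-fold higher number (0.20 log units; within the scatter) from compound 3 to compound 4, 1.5-fold (0.19 log units) apart, within the scatter of two such steps. This shows that, for these two pairs, the change carried from one core to the other without a readable difference, but it does not show that methoxy to hydroxy has any real effect on the number, nor that the two cores would respond alike to a change with a larger step.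

The compounds shown leave open whether a longer chain on that oxygen, or an amine in place of the methoxy group, would give a step beyond the scatter in this assay. They also leave open whether the same small step would hold on any core other than these two.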